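The compounds below may be only part of what the source reports. "The series", "measured", "known", "first", "only" and "open" are said of these compounds alone.

In an ADME assay on L1210/0 cells (Mus musculus) for cytotoxicity, with a stated time of 48 h (a higher number here means a weaker inhibitor, a lower number a stronger inhibitor), compound 1 `OC[C@H]1C[C@@H](Cn2cnc3c(-c4ccc(Cl)cc4)ncnc32)c2ccccc21` gives 8440 nM. Compound 2 `O=c1[nH]c(=O)n([C@H]2C[C@H](O)[C@@H](CO)O2)cc1/C=N/O` gives 15500 nM in this assay; the two numbers lie within the usual scatter of each other, so on the data at hand compound 2 is not set apart from compound 1. Compound 3 `CCCC/C=C\c1cn([C@H]2C[C@H](O)[C@@H](CO)O2)c(=O)[nH]c1=O` differs from compound 2 by a single change on the shared core: a group of 6 heavy atoms (6 carbon; no ring) in place of a group of 3 heavy atoms (1 carbon, 1 nitrogen, 1 oxygen; no ring), on an aromatic carbon. Among the measured compounds shown here, no measured step of this kind exists. In this assay a step of a 1.3-fold higher number from compound 2 to compound 3 (0.11 log units; within the scatter) is expected, with no change beyond the scatter in either direction. For compound 3 the estimate in this assay is 20000 nM, ranging from 5000 nM to 80000 nM.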

Compound 3, half-maximal inhibitory concentration: > 200000 nM
Compound 3: a limit, no number; the forecaster's own chance of this, stated with the estimate: 25%; middle value at least 10-fold (1.00 log units) away from the limit.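

In this assay, among the compounds shown here, hex-1-en-1-yl in place of the group of 3 heavy atoms on this aromatic carbon gives an at least 12-fold higher number from compound 2 to compound 3 (1.11 log units; beyond the scatter), the only step so far, and it shows that the read-out responds to a change at this position. The direction is towards weaker inhibition. Compound 3 carries a limit, not a number: the limit of > 200000 nM in this assay, at which 1 of the 3 values shown sits.

The compounds shown leave open whether the shift tracks the hex-1-en-1-yl chain itself or the absence of the hydrogen-bond donor and acceptors of the group it replaces. An amine or a shorter propyl chain on this carbon would bear on that question.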